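This account rests on a few compounds, and the source may have more. Where it says the series, first, only, none or still open, it means among the compounds named here.

Measured compounds:
Compound 1 `COc1cccc(CNCCCNc2ccnc3cc(Cc4ccccc4)ccc23)c1O`: 4200 nM
Compound 2 `COc1cccc(CNCCCNc2ccnc3cc(CCc4ccccc4)ccc23)c1O`: 4200 nM

In a physicochemical assay for solubility, with a stated time of 18 h, at pH 7.4 (a lower number here means a less soluble compound, a higher number a more soluble compound), compound 2 gives 4200 nM, level with compound 1 at the digits shown; the step of no change at the digits printed from compound 1 to compound 2 (within the scatter) lies within the scatter. The next compound, compound 3 `COc1cccc(CNCCCNc2ccnc3cc(C4CCCCC4)ccc23)c1O`, differs from compound 2 in one place: cyclohexyl in place of phenethyl on an aromatic carbon. Among the compounds with values here, the only measured step that bears on this position is no change at the digits printed from compound 1 to compound 2 (within the scatter), which exchanged phenyl for benzyl and produced no change beyond the scatter. Within the data shown here, no measured step exchanges an aromatic ring for a non-aromatic ring at this position, so the present change goes a little further than anything recorded. On the evidence of that single flat step, the step from compound 2 to compound 3 is expected to be no change at the digits printed from compound 2 to compound 3 (within the scatter), no change beyond the scatter. Compound 3 is therefore estimated at 4200 nM in this assay, with a range from 1500 nM to 12000 nM.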

Compound 3, solubility: 4200 nM
Compound 3: the middle estimate sits on the measured number at the digits printed, within the range that was stated.
By their numbers in this assay, from the lowest: compounds 1, 2 and 3 (each within the scatter of the next).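

In this assay, the exchange of phenethyl for cyclohexyl on this aromatic carbon replaces a six-membered aromatic ring with a non-aromatic one and eight heavy atoms with six, yet the result is no change at the digits printed from compound 2 to compound 3 (within the scatter) and not a shift. Set against the benzyl group, the same ring gives no change at the digits printed from compound 1 to compound 3 (within the scatter), so the reading at this position now holds across a change of ring type as well as the change of chain length seen earlier. Nothing at hand explains why these three groups read alike.

On these data alone, all three groups are built of carbon alone, so it remains open whether an amine or a carboxylic acid on this aromatic carbon would leave the reading in place. As far as these compounds go, it is equally open whether a longer chain bearing the phenyl ring would do so.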